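Cyclopentyl for methyl on the amide nitrogen of compound 2

The compounds below may be only part of what the source reports. "The series", "measured", "known", "first", "only" and "open" are said of these compounds alone.

Three compounds share a core with an alkyne-linked aryl group and have been measured in an assay on HEK293 cells for displacement of a labelled ligand from metabotropic glutamate receptor 5 (Homo sapiens), with a stated time of 2 h; a lower number here means a stronger inhibitor, a higher number a weaker inhibitor. Compound 1 `Cc1ccc(C#Cc2ccc3c(n2)CCN(C)C3=O)cc1` gives 7450 nM in this assay, compound 2 `CN1CCc2nc(C#Cc3ccc(Cl)cc3)ccc2C1=O` gives 6150 nM, and compound 3 `CN1CCc2nc(C#Cc3cccnc3)ccc2C1=O` gives 27400 nM. Compound 2 holds the lowest of the three numbers, but the step that leads to it lies within the scatter (a 1.2-fold lower number from compound 1 to compound 2 (0.08 log units; within the scatter)), while compound 3 sits clearly apart (a 4.5-fold higher number from compound 2 to compound 3 (0.65 log units; beyond the scatter)). Compound 4 `O=C1c2ccc(C#Cc3ccc(Cl)cc3)nc2CCN1C1CCCC1` differs from compound 2 in a single place: cyclopentyl in place of methyl on an amide-type nitrogen in a ring. Among the measured compounds shown here, none of the measured steps touches this nitrogen; all three concern the aryl group on the triple-bonded carbon, where swapping 4-methylphenyl for pyridin-3-yl gave a 3.7-fold higher number from compound 1 to compound 3 (0.57 log units; beyond the scatter). The data therefore offer no direct guide for the change at the amide nitrogen. Compound 4 is expected to stay close to compound 2, with a 1.5-fold lower number from compound 2 to compound 4 (0.19 log units; within the scatter) as the estimated step. The estimate for compound 4 in this assay is 4000 nM, with a range from 1000 nM to 20000 nM.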

Compound 4, inhibition constant: > 32000 nM
Compound 4: no number, only a limit (the forecaster's own chance of this, stated with the estimate: 15%); middle value at least 8.0-fold (0.90 log units) from the limit.
By their numbers in this assay, from the lowest: compounds 2 and 1 (each within the scatter of the next); then compound 3. At a limit, above all of these: compound 4.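

Among the compounds shown here, the amide-type nitrogen in the ring, which none of the earlier steps touched, proves not to be a neutral position in this assay: cyclopentyl in place of methyl there gives an at least 5.2-fold higher number from compound 2 to compound 4 (0.71 log units; beyond the scatter). Up to this point, only changes to the aryl group on the triple-bonded carbon had moved the number beyond the scatter, so this is the first sign that the nitrogen substituent counts as well. Compound 4 gives a limit of the assay and not a number: the limit of > 32000 nM in this assay, at which 1 of the 4 values shown sits.

The compounds shown carry only methyl and cyclopentyl on this nitrogen, which leaves open how an ethyl group, a longer chain or a chain bearing an amine would read. Going by these compounds, it also remains open whether cyclopentyl has the same effect alongside 4-methylphenyl or pyridin-3-yl on the triple-bonded carbon.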